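This account rests on a few compounds, and the source may have more. Where it says the series, first, only, none or still open, it means among the compounds named here.

Compound 2 `CCC(c1nc2ccc(Cl)cc2[nH]1)[C@H]1CC[C@@H](c2ccnc3ccc(F)cc32)CC1` holds the lowest number of the two measured here: in an assay on blood for inhibition of Indoleamine 2,3-dioxygenase 1 (Homo sapiens), read by mass spectrometry, with a stated time of 18 h (a higher number here means a weaker inhibitor, a lower number a stronger inhibitor), compound 2 gives 9 nM, whereas compound 1 `CCC(c1nc2ncc(Cl)cc2[nH]1)[C@H]1CC[C@@H](c2ccnc3ccc(C(F)(F)F)cc32)CC1` gives 21 nM, a gap that lies beyond the scatter. Compound 3 `CCC(c1nc2ncc(Cl)cc2[nH]1)[C@H]1CC[C@@H](c2ccnc3ccc(F)cc32)CC1` has not yet been measured. It differs from compound 2 in one place: a group of 10 heavy atoms (6 carbon, 3 nitrogen, 1 chlorine; one five-membered aromatic ring with 2 hetero atoms, one six-membered aromatic ring with 1 hetero atom) in place of a group of 10 heavy atoms (7 carbon, 2 nitrogen, 1 chlorine; one five-membered aromatic ring with 2 hetero atoms, one six-membered aromatic ring of carbon only), on a saturated chain carbon bound to a saturated chain carbon and a saturated ring carbon. Going by the values given here, no single step of this kind has been measured, and compound 1 and compound 2 differ in two places at once, so their values alone cannot isolate this change. In this assay the expected step is a 1.7-fold higher number from compound 2 to compound 3 (0.22 log units; within the scatter), small and, if anything, toward a slightly weaker inhibitor. Compound 3 is estimated at 15 nM, within a range of 6 nM to 40 nM.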

Compound 3, half-maximal inhibitory concentration: 6 nM
Beside the measured number, compound 3's estimate is 2.5-fold (0.40 log units) above it; low and high end bracket the measured number.
By their numbers in this assay, from the lowest: compounds 3 and 2 (each within the scatter of the next); then compound 1.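

Replacing the 6-chloro-1H-benzimidazol-2-yl group with the group carrying a six-membered aromatic ring with 1 hetero atom gives a 1.5-fold lower number from compound 2 to compound 3 (0.18 log units; within the scatter) in this assay, so this place on the saturated chain carbon accepts the ring hetero atom with no shift beyond the scatter. Compound 3 also isolates the second change, fluoro in place of trifluoromethyl on an aromatic carbon, which gives a 3.5-fold lower number from compound 1 to compound 3 (0.54 log units; beyond the scatter). No measurement on hand explains either step. Still open, on these data alone, is how a methoxy group or a nitrile on that aromatic carbon would read, and how a bromine in place of the chlorine would.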